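Amide series: from fluorophenyl toward cyclohexyl amide

The source may report more compounds than this note shows. Statements on the series, on what has been measured and on what is new or still open speak of the compounds shown alone.

Three amides of the shared core have been measured. Compound 1 `COc1cc(-c2cc(C(=O)O)c3ccccc3n2)ccc1OCC(=O)Nc1ccccc1F` carries a 2-fluorophenyl group on the amide nitrogen; in a physicochemical assay for lipophilicity, using the shake flask method, in phosphate buffer, measured as octanol-water partition, at pH 7.4 (a lower number here means a more polar compound, a higher number a more lipophilic compound), compound 1 gives 0.9, the lowest of the three numbers. Compound 2 `COc1cc(-c2cc(C(=O)O)c3ccccc3n2)ccc1OCC(=O)Nc1ccccc1Cl` gives 1.6, and compound 3 `COc1cc(-c2cc(C(=O)O)c3ccccc3n2)ccc1OCC(=O)Nc1ccccc1C(F)(F)F` gives 1.3. Both replacements at the aromatic carbon moved the number upward: a number 0.70 log units higher from compound 1 to compound 2 (beyond the scatter) and a number 0.40 log units higher from compound 1 to compound 3 (beyond the scatter). Between the two heavier substituents the step is a number 0.30 log units lower from compound 2 to compound 3 (within the scatter).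

Compound 4 `COc1cc(-c2cc(C(=O)O)c3ccccc3n2)ccc1OCC(=O)NC1CCCCC1` differs from compound 1 as follows: cyclohexyl in place of 2-fluorophenyl on an amide-type nitrogen. Among the compounds with values here, none of the measured steps alters the ring itself; all three keep the phenyl ring on the amide nitrogen and vary only its substituent, so none bears directly on this change, and the expectation rests on the series as a whole rather than on a matching step. A modest rise is nonetheless expected because a number 0.70 log units higher from compound 1 to compound 2 (beyond the scatter) and a number 0.40 log units higher from compound 1 to compound 3 (beyond the scatter) both show that every variation of the amide substituent so far has raised the number from compound 1, though the uncertainty here is wide. The estimated step is a number 0.60 log units higher from compound 1 to compound 4 (beyond the scatter). For compound 4 the expected value is 1.5, within 0.8 to 2.2.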

Compound 4, distribution coefficient: 0.8
Beside the measured number, compound 4's estimate is 0.70 log units above it; the range from low to high includes it.
By their numbers in this assay, from the lowest: compounds 4 and 1 (each within the scatter of the next); then compounds 3 and 2 (each within the scatter of the next).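

Working from this assay, cyclohexyl in place of 2-fluorophenyl on an amide-type nitrogen gives a number 0.10 log units lower from compound 1 to compound 4 (within the scatter) and is the first change at this position that does not separate a compound from compound 1. The earlier steps shown here varied only the substituent on an aromatic ring, whereas this one exchanges the aromatic ring for a non-aromatic ring of carbon only and removes the fluorine in the same step. Against the other two phenyl amides the change reads as a number 0.50 log units lower from compound 3 to compound 4 (beyond the scatter) and as a number 0.80 log units lower from compound 2 to compound 4 (beyond the scatter), and no available data explain these results.

Within the data shown here, the single step cannot separate the contribution of the ring change from that of losing the fluorine, and an unsubstituted phenyl group on the same nitrogen would be the compound to compare with both compound 1 and compound 4. On these data alone, how far the number at this position depends on ring size or on a group carried by the ring stays open for a cyclopentyl ring, a longer alkyl chain, or a cyclohexyl ring bearing an amine or a hydroxyl group.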